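The source may report more compounds than this note shows. Statements on the series, on what has been measured and on what is new or still open speak of the compounds shown alone.

Measured compounds:
compound 1 `N[C@@H]1CCN(c2cc3c(cc2F)c(=O)c(C(=O)O)cn3Cc2ccc(-c3ccccc3)cc2)C1` with 63600 nM
compound 2 `CN[C@@H]1CCN(c2c(F)cc3c(=O)c(C(=O)O)cn(Cc4ccc(-c5ccccc5)cc4)c3c2OC)C1` with 57700 nM
compound 3 `COc1c(N2CC[C@@H](CN)C2)c(F)cc2c(=O)c(C(=O)O)cn(Cc3ccc(-c4ccccc4)cc3)c12` with 26000 nM

In an assay on isolated protein for inhibition of DNA topoisomerase 1 (Homo sapiens), with a stated time of 15 min (a lower number here means a stronger inhibitor, a higher number a weaker inhibitor), compound 3 stands at the lowest of the three numbers. Its nearest neighbour is compound 2, where a 2.2-fold lower number from compound 2 to compound 3 (0.35 log units; beyond the scatter) separates the two. Compound 1 is the furthest from it; the pair differs in more than one place, so only the two values can be compared, and compound 1 gives the higher number.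

Compound 4 `COc1c(N2CC[C@@H](N)C2)c(F)cc2c(=O)c(C(=O)O)cn(Cc3ccc(-c4ccccc4)cc3)c12` is the next step. It differs from compound 3 in one place: amino in place of aminomethyl on a saturated ring carbon. Within the data shown here, the only measured step at the same position is the one from compound 2 to compound 3, and it was modest, so a change of similar size is the most that the data support here. Nothing measured ties the amino group on this position to a particular direction. The step of a 1.5-fold higher number from compound 3 to compound 4 (0.19 log units; within the scatter) is therefore expected to be small, with a slight rise in the number considered somewhat more likely than a fall. Compound 4 is estimated at 40000 nM, within 15000 nM to 110000 nM.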

Compound 4, half-maximal inhibitory concentration: 92200 nM
For compound 4 the middle estimate is 2.3-fold (0.36 log units) below the measured one, and the stated range covers the measured number.
By their numbers in this assay, from the lowest: compound 3; then compounds 2, 1 and 4 (each within the scatter of the next).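

In this assay, the aminomethyl group on this saturated ring carbon now stands apart from both groups that carry the nitrogen directly on the ring, with a 3.5-fold higher number from compound 3 to compound 4 (0.55 log units; beyond the scatter) beside the earlier 2.2-fold lower number from compound 2 to compound 3 (0.35 log units; beyond the scatter). Among those two groups, hydrogen in place of methyl on the amine nitrogen leaves no readable difference, with a 1.6-fold higher number from compound 2 to compound 4 (0.20 log units; within the scatter). The 3-aminopyrrolidin-1-yl compounds also show no readable effect of methoxy in place of hydrogen on an aromatic carbon, with a 1.4-fold higher number from compound 1 to compound 4 (0.16 log units; within the scatter).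

Nothing in the data accounts for the lower number with aminomethyl. As far as these compounds go, it remains open whether a longer chain such as aminoethyl, or a hydroxymethyl group, on the same ring carbon would lower the number further, and whether methoxy matters when aminomethyl is present.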